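The source may hold more compounds than are shown below. What is called first, only, known or untested is meant among the compounds shown, and "the series" means these compounds.

Series around the shared core of compound 1 `COc1cc2c(cc1OC)C(CC(=O)N(C)C)CC2`. For the measured compounds named here, in a functional assay on the whole organism (strain Wistar) for inhibition, with Rattus norvegicus as the target, read by paw edema, with stated times of 60 min and 2 h, at a dose of 100 mg/kg by the oral route (on this read-out higher numbers stand for more inhibition at the one dose given (going by the name of the read-out) and lower numbers for less inhibition), compound 1 gives 36%, the higher of the two numbers measured so far. Compound 2 `CCCNC(=O)CC1CCc2cc(OC)c(OC)cc21` carries propylamino in place of dimethylamino on the carbonyl carbon; in this assay compound 2 gives 28%, and the step of a number 8 percentage points lower from compound 1 to compound 2 (within the scatter) lies within the scatter of repeated measurements, so the two values cannot be ordered.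

Compound 3 `CCCCNC(=O)CC1CCc2cc(OC)c(OC)cc21` is not yet measured. It differs from compound 1 as follows: butylamino in place of dimethylamino on a carbonyl carbon. Going by the values given here, the only measured step that bears on this change is the exchange of dimethylamino for propylamino on the same carbonyl carbon, a number 8 percentage points lower from compound 1 to compound 2 (within the scatter), and it was small. Butylamino in place of dimethylamino is a change of the same kind, one chain carbon longer, so no step beyond the scatter is expected in this assay; the estimate leans toward a value near that of compound 2 rather than above compound 1. The expected step is a number 8 percentage points lower from compound 1 to compound 3 (within the scatter). Compound 3 is estimated at 28% in this assay, with a range from 15% to 41%.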

Compound 3, a percentage reported as inhibition, in the whole organism at one dose (the size of the read-out at that dose, not a potency): 24%
Beside the measured number, compound 3's estimate is 4 percentage points above it; the measured number falls inside the stated range.
By their numbers in this assay, from the lowest: compounds 3, 2 and 1 (each within the scatter of the next, the first and the last beyond it).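

In this assay, butylamino in place of dimethylamino on the carbonyl carbon gives a number 12 percentage points lower from compound 1 to compound 3 (beyond the scatter), so a change at this position can move the read-out beyond the scatter, though the step is modest. The one further chain carbon, read alone, gives a number 4 percentage points lower from compound 2 to compound 3 (within the scatter), so propylamino and butylamino cannot be ordered, and these compounds establish no graded effect of chain length. The change from dimethylcarbamoyl to butylcarbamoyl lengthens the chain and also brings in the amide hydrogen, and no available measurement separates these two differences or explains the step.

Dibutylamino, which has longer chains without the amide hydrogen, and methylamino, which has a short chain with that hydrogen, would help separate the two differences. Hexylamino would test whether the read-out keeps falling with a longer chain, while a carboxylic acid in place of the amide would show how much of the inhibition at this dose depends on the amide itself.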